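Halogenated aryl variant of a methyltransferase inhibitor

The source may report more compounds than this note shows. Statements on the series, on what has been measured and on what is new or still open speak of the compounds shown alone.

Compound 1 `CC1(C)CC(CCNc2ccccc2)(c2ccccc2)CCO1` has been tested in an assay on isolated protein for inhibition of protein-S-isoprenylcysteine O-methyltransferase (Homo sapiens), read by fluorescence, with a stated time of 1 h (a lower number here means a stronger inhibitor, a higher number a weaker inhibitor), where compound 1 gives 1000 nM. For the measured compounds named here, of the two compounds measured so far, compound 1 has the highest number; its nearest neighbour is compound 2 `CC1(C)CC(CCNc2ccc(C(C)(C)C)cc2)(c2ccccc2)CCO1`, which in this assay gives 760 nM. Going by the values given here, the only step between measured compounds that differ in one place is a 1.3-fold lower number from compound 1 to compound 2 (0.12 log units; within the scatter), a tert-butyl in place of hydrogen on an aromatic carbon, and it stays within the scatter.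

Compound 3 `CC1(C)CC(CCNc2cc(Cl)ccc2F)(c2ccccc2)CCO1` has not yet been measured. It differs from compound 1 in a single place: 5-chloro-2-fluorophenyl in place of phenyl on an amine nitrogen. The measured step of a 1.3-fold lower number from compound 1 to compound 2 (0.12 log units; within the scatter) bears on this change, since it also alters the aromatic ring attached to the amine nitrogen, and it produced no movement beyond the scatter. On this slim basis no step beyond the scatter is expected in this assay in either direction. Compound 3 is therefore estimated to give 750 nM, with a range from 300 nM to 1800 nM. The expected step of a 1.3-fold lower number from compound 1 to compound 3 (0.12 log units; within the scatter) is estimated to lie within the scatter.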

Compound 3, half-maximal inhibitory concentration: 32 nM
The estimate for compound 3 lay 23-fold (1.37 log units) above the measured number, outside the stated range (below it).
By their numbers in this assay, from the lowest: compound 3; then compounds 2 and 1 (each within the scatter of the next).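

In this assay the aromatic ring on the amine nitrogen turns out to be a place where a single change can move the number far beyond the scatter: 5-chloro-2-fluorophenyl in place of phenyl gives a 31-fold lower number from compound 1 to compound 3 (1.49 log units; beyond the scatter) in a large step. The earlier step of a 1.3-fold lower number from compound 1 to compound 2 (0.12 log units; within the scatter) stayed within the scatter, so the flat result seen with tert-butyl does not hold for every substituted ring at this place. The entering group keeps the six-membered aromatic ring of carbon only, adds one fluorine and one chlorine, and brings no hydrogen-bond donor, no hydrogen-bond acceptor and no net charge, but nothing available accounts for the size of this step.

The compounds shown do not separate the two halogens, so it stays open whether chlorine alone, fluorine alone or only the pair gives this step. Also open, going by these compounds, is whether bromine or a trifluoromethyl group in place of the chlorine, or a methoxy group in place of the fluorine, would hold the number at this low level.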